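The compounds below may be only part of what the source reports. "The series", "measured", "known", "first", "only" and "open" are said of these compounds alone.

Measured so far in an assay on Cerebral cortex for binding affinity to adenosine receptor A1 (Cavia porcellus), read by radioligand binding; on this read-out lower numbers stand for stronger inhibition and higher numbers for weaker inhibition:
compound 1 `C=CCn1c(=O)c2[nH]cnc2n(CCC)c1=O` gives 1700 nM;
compound 2 `CCCn1c(=O)n(CC(=O)O)c(=O)c2[nH]cnc21` gives > 200000 nM.

Compound 2 sits at a limit of this assay rather than at a number: its reading is > 200000 nM, the same limit noted as the limit of > 200000 nM in this assay, at which 1 of the 2 values shown sits. Among the measured compounds shown here, compound 1, carrying the vinyl chain on the same core, is the only compound of the pair with a numeric value, and the step of an at least 110-fold higher number from compound 1 to compound 2 (2.07 log units; beyond the scatter) shows how far the carboxy-bearing analogue falls behind it.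

Compound 3 `CCCn1c(=O)n(CCC(=O)O)c(=O)c2[nH]cnc21` is not yet measured. It differs from compound 2 by carboxymethyl in place of carboxy on a saturated chain carbon bound to an aromatic nitrogen; the carboxy group is kept and moved one chain carbon further out. For the measured compounds named here, the one measured step, from compound 1 to compound 2, concerns the arrival of the carboxy group, not its distance from the core, so it bears on compound 3 only in that the acid remains. Compound 3 is therefore expected to stay weak, with the step of a number no higher from compound 2 to compound 3 (the limit leaves the size open) estimated as none beyond the scatter. Compound 3 is estimated at 200000 nM in this assay, with a range from 50000 nM to 600000 nM, and most likely reported again only as a limit.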

Compound 3, inhibition constant: > 200000 nM
Compound 3: a limit, no number; the forecaster's own chance of this, stated with the estimate: 70%; the middle value sits exactly at the limit.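

Compound 3 is reported in this assay only as a limit, > 200000 nM. At this saturated chain carbon bound to an aromatic nitrogen, moving the carboxy group one chain carbon further out therefore gives no numeric reading, and the carboxymethyl chain still falls well short of the vinyl chain, with an at least 110-fold higher number from compound 1 to compound 3 (2.07 log units; beyond the scatter). The step between compound 2 and compound 3 cannot be read, so the effect of the added chain carbon on the acid remains unknown, and the two acids can only be recorded at the same limit: the limit of > 200000 nM in this assay, at which 2 of the 3 values shown sit.

On these data alone, the order of the two acids, and the size of any gap between them, stay open. Also open, as far as these compounds go, is whether a methyl ester or an amine at the end of this chain would give a numeric reading, as compound 1 does, which would help separate the role of the carboxylic acid from that of the chain carrying it.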